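The compounds below may be only part of what the source reports. "The series", "measured", "known", "first", "only" and "open" are said of these compounds alone.

Values so far in a functional assay on HL-60 cells (Homo sapiens) for inhibition, read by MTT assay, with a stated time of 72 h, tested at 50 uM (a lower number here means less inhibition of growth, a higher number more inhibition of growth at the concentration tested), are these:
- compound 1 `C=CCc1ccc(OCc2cn(-c3cccc([N+](=O)[O-])c3)nn2)c(O)c1` gives 65.5%
- compound 2 `C=CCc1ccc(OCc2cn(-c3ccccc3Cl)nn2)c(O)c1` gives 43.2%
- compound 3 `C#CCOc1ccc(CC=C)cc1O` gives 34.2%

Compound 1 stands highest of these three, and its gaps down to compound 2 and to compound 3 both lie beyond the usual scatter. Compound 4 `C=CCc1ccc(OCc2cn(-c3cccc(C#N)c3)nn2)c(O)c1` is compound 1 with cyano in place of nitro on an aromatic carbon. Among the compounds with values here, no measured pair here isolates a single change, so this swap has no direct precedent. Compound 1 at 65.5% is the top number here, so a lower reading seems somewhat likelier than a higher one. The expected change is a modest fall, an estimated step of a number 7.5 percentage points lower from compound 1 to compound 4 (within the scatter) in this assay that may not clear the scatter. For compound 4 the estimated value is 58% with 42% to 72% as the expected range.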

Compound 4, percent growth inhibition at one concentration: 30.9%
Estimate against measurement, compound 4: 27.1 percentage points above, and the stated range ends above it.
By their numbers in this assay, from the lowest: compounds 4, 3 and 2 (each within the scatter of the next, the first and the last beyond it); then compound 1.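

In this assay, cyano in place of nitro on this aromatic carbon is far from a neutral swap: it gives a number 34.6 percentage points lower from compound 1 to compound 4 (beyond the scatter) and shows that growth inhibition depends strongly on the group held here. Replacing 2-chlorophenyl with 3-cyanophenyl on the aromatic nitrogen also gives a number 12.3 percentage points lower from compound 2 to compound 4 (beyond the scatter), so the cyano-bearing ring offers no gain over that chlorinated one. Nothing available explains why either number falls.

Going by these compounds, whether nitro is unusual at this position remains open. An amine or a carboxylic acid on the same carbon would help show how much of the inhibition depends on nitro itself.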